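Series notes: nitro to methyl on the aryl ring

This account rests on a few compounds, and the source may have more. Where it says the series, first, only, none or still open, it means among the compounds named here.

Measured compounds and their values in a functional assay on MCF7 cells (Homo sapiens) for antiproliferative activity, read by MTT assay, with a stated time of 96 h; a lower number here means a stronger inhibitor, a higher number a weaker inhibitor:
compound 1, `O=C1NNC(=O)C2(CSC3=C2C(=O)c2ncccc2C3=O)N1`, 1250 nM
compound 2, `O=C1C2=C(C(=O)c3ncccc31)C1(CS2)NC(=O)N(c2ccc([N+](=O)[O-])cc2)C1=O`, 350 nM
compound 3, `CCc1ccc(N2C(=O)NC3(CSC4=C3C(=O)c3ncccc3C4=O)C2=O)cc1`, 50 nM

Within this assay compound 2 stands second highest of the three numbers; the nearest value is that of compound 1, the furthest that of compound 3, and both gaps lie beyond the scatter.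

The step under consideration goes from compound 2 to compound 4, `Cc1ccc(N2C(=O)NC3(CSC4=C3C(=O)c3ncccc3C4=O)C2=O)cc1`, not yet measured. The change is methyl in place of nitro on an aromatic carbon.

Among the measured compounds shown here, one measured step bears on it: a 7.0-fold lower number from compound 2 to compound 3 (0.85 log units; beyond the scatter). There the same nitro group left the same position and a small alkyl, ethyl, entered; here the entering group is methyl, one heavy atom in place of two. The two steps are of the same kind, so a move in the same direction, to a lower number, is expected, though the step is estimated somewhat smaller than the step from compound 2 to compound 3.

On that basis compound 4 is expected to give about 80 nM in this assay, within a range of 30 nM to 250 nM. This estimate means a step of a 4.4-fold lower number from compound 2 to compound 4 (0.64 log units; beyond the scatter).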

Compound 4, half-maximal inhibitory concentration: 2 nM
The estimate for compound 4 lay 40-fold (1.60 log units) above the measured number; the whole stated range lies above it.
By their numbers in this assay, from the lowest: compound 4; then compound 3; then compound 2; then compound 1.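

In this assay, among the compounds shown here, the change from 4-nitrophenyl to 4-methylphenyl gives a 180-fold lower number from compound 2 to compound 4 (2.24 log units; beyond the scatter), so the para carbon of this aryl ring carries far more of the series' range than the earlier compounds showed. Those compounds showed only that ethyl in place of nitro lowers the number; the further step in this assay, a 25-fold lower number from compound 3 to compound 4 (1.40 log units; beyond the scatter), shows that small alkyl groups at this position are not interchangeable and that a single carbon of chain length separates them by a large margin. Nothing at hand accounts for the size of either step.

The compounds shown leave open whether methyl marks a sharp optimum at this position or whether other small groups, such as a chloro, a methoxy or a hydroxyl group, or hydrogen itself, would reach a similar number, and a propyl chain would show whether the rise from methyl to ethyl continues with length. They also leave open how an amine or a carboxylic acid on the same carbon would compare with nitro.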